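Moving from dimethyl to ethyl on the sulfonamide aryl

This account rests on a few compounds, and the source may have more. Where it says the series, first, only, none or still open, it means among the compounds named here.

Measured compounds:
- compound 1 `COc1ccccc1NS(=O)(=O)c1ccc(N2CCNC2=O)cc1`: 550 nM
- compound 2 `COc1cccc(NS(=O)(=O)c2ccc(N3CCNC3=O)cc2)c1`: 120 nM
- compound 3 `Cc1ccc(NS(=O)(=O)c2ccc(N3CCNC3=O)cc2)cc1C`: 230 nM

In a functional assay on HT-29 cells (Homo sapiens) for antiproliferative activity, read by sulforhodamine B assay, with a stated time of 48 h (on this read-out lower numbers stand for stronger inhibition and higher numbers for weaker inhibition), compound 3 gives 230 nM, the second highest number of the three. Its nearest neighbour is compound 2, which gives 120 nM; the two sit within the scatter, as the step of a 1.9-fold higher number from compound 2 to compound 3 (0.28 log units; within the scatter) shows. The furthest is compound 1, which gives 550 nM; the step of a 2.4-fold lower number from compound 1 to compound 3 (0.38 log units; beyond the scatter) lies beyond the scatter.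

Compound 4 `CCc1cccc(NS(=O)(=O)c2ccc(N3CCNC3=O)cc2)c1` has not yet been measured. It differs from compound 3 in one place: 3-ethylphenyl in place of 3,4-dimethylphenyl on a sulfonamide nitrogen. For the measured compounds named here, no measured step swaps these two groups directly. The closest comparison is the step of a 1.9-fold higher number from compound 2 to compound 3 (0.28 log units; within the scatter), where one group on the sulfonamide nitrogen was exchanged for another of similar size without a change beyond the scatter. On that basis, the step from compound 3 to compound 4 is expected to stay within the scatter, with no clear direction, as a 1.2-fold lower number from compound 3 to compound 4 (0.06 log units; within the scatter) expresses. Compound 4 is therefore estimated at 200 nM, within a range from 90 nM to 450 nM.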

Compound 4, half-maximal inhibitory concentration: 110 nM
Beside the measured number, compound 4's estimate is 1.8-fold (0.26 log units) above it, within the range that was stated.
By their numbers in this assay, from the lowest: compounds 4, 2 and 3 (each within the scatter of the next, the first and the last beyond it); then compound 1.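

In this assay, 3-ethylphenyl and 3,4-dimethylphenyl on the sulfonamide nitrogen have the same atoms joined differently, yet the exchange gives a modest step (a 2.1-fold lower number from compound 3 to compound 4 (0.32 log units; beyond the scatter)), so the arrangement of those atoms matters and not only their number. Ethyl in place of methoxy on an aromatic carbon leaves the number within the scatter (a 1.1-fold lower number from compound 2 to compound 4 (0.04 log units; within the scatter)), while 3-ethylphenyl in place of 2-methoxyphenyl gives a modest step beyond it (a 5.0-fold lower number from compound 1 to compound 4 (0.70 log units; beyond the scatter)). Nothing available here accounts for any of these steps.

Still open, on these data alone, is whether a longer chain such as propyl, or an amine or a carboxylic acid, could take the place of the ethyl group and hold the number in this range. These results also cannot show whether the same steps would appear in other cell lines.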